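Dropping one chloro from the aromatic ring of compound 2

This account rests on a few compounds, and the source may have more. Where it says the series, first, only, none or still open, it means among the compounds named here.

Compound 1 `C=C(c1ccc(F)c(F)c1)C1COC(C)(C)OO1` and compound 2 `C=C(c1ccc(Cl)c(Cl)c1Cl)C1COC2(CCCCC2)OO1` were tested in a functional assay on L02 cells (Homo sapiens) for inhibition, read by MTT assay, with a stated time of 72 h; a lower number here means a stronger inhibitor, a higher number a weaker inhibitor. For compound 1 this assay reports only a limit, > 100000 nM. Compound 2 gives 1220 nM in this assay, and that is the only number shown. The other value shown is a limit, (the limit of > 100000 nM in this assay, at which 1 of the 2 values shown sits). Within the data shown here, no step between two measured compounds that differ in a single place is available, so compound 2 serves as the sole anchor for what follows.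

Compound 3 `C=C(c1ccc(Cl)cc1Cl)C1COC2(CCCCC2)OO1` has not yet been measured in this assay. It differs from compound 2 by hydrogen in place of chloro on an aromatic carbon. Among the measured compounds shown here, with only one measured number and no measured step for guidance, the expectation is a moderate loss of inhibition, somewhat beyond the usual scatter but not large, with the step from compound 2 to compound 3 estimated as a 2.5-fold higher number from compound 2 to compound 3 (0.39 log units; beyond the scatter). Compound 3 is therefore expected to give about 3000 nM in this assay, most plausibly between 1000 nM and 12000 nM.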

Compound 3, half-maximal inhibitory concentration: 3690 nM
Beside the measured number, compound 3's estimate is 1.2-fold (0.09 log units) below it; low and high end bracket the measured number.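

In this assay, among these compounds, hydrogen in place of chloro on an aromatic carbon, ortho to two chloro groups, gives a 3.0-fold higher number from compound 2 to compound 3 (0.48 log units; beyond the scatter), the first step that can be read between two compounds differing in one place. This chloro therefore matters to the inhibition, although the step is modest and compound 3, with its two remaining chloro groups, still gives a measured number rather than a limit. Nothing measured here bears on why the number moves with this change.

From the compounds shown here alone, whether a fluoro, a methyl, a methoxy or an amine at this place would give a number nearer that of compound 2 or that of compound 3 remains open, as does the effect of replacing either remaining chloro group with hydrogen. Compound 1 differs from compound 2 and compound 3 in more than one place and shows only a limit, so it gives no measure of what this position contributes on its own.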